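Compound 4: Expected Tolerance Beside Three Measured Limits

A few compounds are considered here, and "the series" means these few. Any claim that something is new, unique, unknown or untested is made for them only; others in the source may bear on it.

Compound 1 `CCCNc1nc(N)nc2c1ncn2/C=C1/CC1(CO)CO`: > 300000 nM
Compound 2 `Nc1nc(NCc2ccccc2)c2ncn(/C=C3/CC3(CO)CO)c2n1`: > 300000 nM
Compound 3 `Nc1nc(NC2CCCC2)c2ncn(/C=C3/CC3(CO)CO)c2n1`: > 300000 nM

In an ADME assay on HFF cells (Homo sapiens) for cytotoxicity, with a stated time of 8 days (a higher number here means that more compound is tolerated, a lower number that less compound is tolerated), compound 1 gives > 300000 nM, a limit rather than a number. Compound 2 likewise stands at a limit, > 300000 nM. Compound 3 also stands at a limit, > 300000 nM. The steps a step that the two limits leave unreadable from compound 1 to compound 2, a step that the two limits leave unreadable from compound 1 to compound 3 and a step that the two limits leave unreadable from compound 2 to compound 3 are therefore all unreadable, since (the limit of > 300000 nM in this assay, at which 3 of the 3 values shown sit). Compound 4 `CCOc1nc(N)nc2c1ncn2/C=C1/CC1(CO)CO` differs from compound 1 by ethoxy in place of propylamino on an aromatic carbon. The measured steps alter the same part of the shared core, yet none shows a readable size, so no step beyond the scatter is expected in this assay. Compound 4 is expected at 300000 nM, between 100000 nM and 1000000 nM, meaning an expected step of a number no higher from compound 1 to compound 4 (the limit leaves the size open).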

Compound 4, half-maximal cytotoxic concentration: > 300000 nM
Compound 4: no number, only a limit (the forecaster's own chance of this, stated with the estimate: 85%); the middle value sits exactly at the limit.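

The steps from compound 1, compound 2 and compound 3 to compound 4 cannot be read in this assay: the limit of > 300000 nM in this assay, at which 4 of the 4 values shown sit.

The compounds shown leave open where the half-maximal cytotoxic concentration of any of them lies, and so whether ethoxy in place of propylamino shifts it at all.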